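The source may report more compounds than this note shows. Statements on the series, on what has been measured and on what is new or still open speak of the compounds shown alone.

Compound 1, `COc1ncnc2c1c(-c1cccs1)cn2[C@@H]1O[C@H](CO)[C@@H](O)[C@H]1O`: in a functional assay on CCRF-CEM cells (Homo sapiens), read by MTT assay, with a stated time of 72 h (on this read-out lower numbers stand for stronger inhibition and higher numbers for weaker inhibition), compound 1 gives 90 nM.
Compound 2, `CNc1ncnc2c1c(-c1cccs1)cn2[C@@H]1O[C@H](CO)[C@@H](O)[C@H]1O`: in this assay compound 2 reaches only the limit > 20000 nM.
Compound 3, `CSc1ncnc2c1c(-c1cccs1)cn2[C@@H]1O[C@H](CO)[C@@H](O)[C@H]1O`: in this assay compound 3 likewise reaches only the limit > 20000 nM.

Compound 2 therefore stands at the edge of what this assay can report; of the three values shown, two sit at the limit of > 20000 nM in this assay, at which 2 of the 3 values shown sit, and compound 1 alone gives a number. The two readable steps both start from compound 1: an at least 220-fold higher number from compound 1 to compound 2 (2.34 log units; beyond the scatter) and an at least 220-fold higher number from compound 1 to compound 3 (2.34 log units; beyond the scatter). The step between the two limits, a step that the two limits leave unreadable from compound 2 to compound 3, cannot be read.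

Compound 4, `C#Cc1cn([C@@H]2O[C@H](CO)[C@@H](O)[C@H]2O)c2ncnc(NC)c12`, keeps the methylamino group of compound 2 and changes the other side of the shared core: ethynyl in place of thiophen-2-yl on an aromatic carbon. Going by the values given here, no measured step touches that position, so none bears directly on this change; what is known is only that compound 2, the starting point, already lies at the limit, and nothing in the measured steps points to a recovery from it. The step expected in this assay is a number no higher from compound 2 to compound 4 (the limit leaves the size open), and the most likely outcome is that compound 4 again reports only a limit. Compound 4 is accordingly estimated at 20000 nM, in a range from 3000 nM to 100000 nM.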

Compound 4, half-maximal inhibitory concentration: > 20000 nM
Compound 4 was reported as a limit; the forecaster's own chance of this, stated with the estimate: 60%; the middle value lies on the limit itself.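

In this assay compound 4 reaches only > 20000 nM, which is a limit and not a number. Going by these compounds alone, compound 2 also stands at a limit, so no step between compound 2 and compound 4 can be read. The compounds shown leave open how ethynyl and thiophen-2-yl compare at this position, with methylamino or with methoxy on the shared core.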